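The compounds below may be only part of what the source reports. "The series", "measured", "known", "first", "only" and "open" are said of these compounds alone.

Compound 1 `CO[C@H]1CC[C@H](CNc2cc(NCc3cnccc3C(F)(F)F)ncc2C#N)CC1`: in an assay on isolated protein for inhibition of protein kinase C delta type (Homo sapiens), read by TR-FRET, with a stated time of 2 h (a lower number here means a stronger inhibitor, a higher number a weaker inhibitor), compound 1 gives > 10000 nM, which is a limit of the assay and not a number.
Compound 2 `N#Cc1cnc(NCc2cncnc2C(F)(F)F)cc1N[C@H]1CC[C@@H](O)CC1`: in this assay compound 2 gives 450 nM.

Compound 2 thus holds the only number shown. The other value belongs to compound 1 and is a limit, (the limit of > 10000 nM in this assay, at which 1 of the 2 values shown sits). Compound 3 `CC(C)(C)Oc1ncncc1CNc1cc(N[C@H]2CC[C@@H](O)CC2)c(C#N)cn1` differs from compound 2 by tert-butoxy in place of trifluoromethyl on an aromatic carbon. Going by the values given here, no measured step is available for comparison, so the step from compound 2 to compound 3 in this assay is expected to be a 1.3-fold higher number from compound 2 to compound 3 (0.12 log units; within the scatter), not beyond the scatter in either direction. Compound 3 is therefore estimated at 600 nM, with a range from 150 nM to 2500 nM.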

Compound 3, half-maximal inhibitory concentration: 200 nM
Compound 3: middle estimate off by 3.0-fold (0.48 log units), on the high side, and the stated range covers the measured number.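

Placing tert-butoxy in place of trifluoromethyl on this aromatic carbon gives a 2.3-fold lower number from compound 2 to compound 3 (0.35 log units; beyond the scatter) in this assay, the first measured step at this position. Trifluoromethyl is therefore not needed here for inhibition, and the modest change runs toward a stronger inhibitor. Nothing measured here gives a reason for this step.

On these data alone, whether methoxy or an amine on the same carbon would keep this gain remains open. So does whether the step would carry over to the other substituents of compound 1.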